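Thiophen-3-yl in place of hydroxyethyl on the shared core

The source may hold more compounds than are shown below. What is called first, only, known or untested is meant among the compounds shown, and "the series" means these compounds.

Compound 1 `Cc1nc(CCO)cc2nn(-c3ccccc3)cc12` in a functional assay on MCF7 cells (Homo sapiens) for inhibition, read by fluorescence, with a stated time of 72 h (on this read-out higher numbers stand for weaker inhibition of growth and lower numbers for stronger inhibition of growth), gives > 100000 nM, which is a limit of the assay and not a number. Compound 2 `OCCc1cc2nn(-c3ccccc3)cc2cn1` in this assay gives > 100000 nM, again a limit. Among the compounds with values here, the one measured step, a step that the two limits leave unreadable from compound 1 to compound 2, hydrogen in place of methyl on an aromatic carbon, cannot be read in size because both values sit at the limit of > 100000 nM in this assay, at which 2 of the 2 values shown sit. Compound 3 `Cc1nc(-c2ccsc2)cc2nn(-c3ccccc3)cc12` carries thiophen-3-yl in place of 2-hydroxyethyl on an aromatic carbon, thiophen-3-yl in place of 2-hydroxyethyl on an aromatic carbon. Within the data shown here, no measured step bears on this change, so neither a direction nor a size of step in this assay can be drawn from the series; the expectation is that compound 3 remains weak, with a fair chance of another limit. The estimated step of an at least 1.6-fold lower number from compound 1 to compound 3 (0.22 log units; that floor lies within the scatter) is taken as none beyond the scatter. Compound 3 is estimated at 60000 nM, within 8000 nM to 300000 nM.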

Compound 3, concentration for 50% growth inhibition: 22200 nM
The estimate for compound 3 lay 2.7-fold (0.43 log units) above the measured number; the range from low to high includes it.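

Within the data shown here, at the aromatic carbon next to the ring nitrogen, thiophen-3-yl in place of 2-hydroxyethyl gives the one readable step in this assay: an at least 4.5-fold lower number from compound 1 to compound 3 (0.65 log units; beyond the scatter). This position therefore responds to substitution, and compound 3 gives 22200 nM, a number rather than a limit. Compound 1 and compound 2 remain at a limit of the assay: the limit of > 100000 nM in this assay, at which 2 of the 3 values shown sit.

Going by these compounds, the step from compound 1 is only a floor, its true size is open, and the step from compound 1 to compound 2 cannot be read, so the effect of the methyl group on the shared core also remains unknown. On these data alone, it is also open whether the change depends on the thiophene ring itself, the aromatic ring in general or the loss of the hydroxyl group, which a phenyl, cyclopentyl or 2-methoxyethyl group at this position could help separate.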